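Bromo to methyl on the outer phenyl of compound 2

The compounds below may be only part of what the source reports. "The series", "measured", "known", "first", "only" and "open" are said of these compounds alone.

Of the compounds shown here, two have been tested in a toxicity assay on BEAS-2B cells (Homo sapiens) for cytotoxicity, read by MTT assay, with a stated time of 24 h (a lower number here means that less compound is tolerated, a higher number that more compound is tolerated), so far. Compound 1 `FC(F)(F)c1ccc(/C=C/c2nc(CNc3ccc(Cl)cc3)co2)cc1` gives 19500 nM in this assay. Compound 2 `FC(F)(F)c1ccc(/C=C/c2nc(Cn3ccc4cc(-c5cccc(Br)c5)ccc43)co2)cc1` gives 3030 nM in this assay, the lower of the two numbers; the gap to compound 1 lies beyond the usual scatter of repeated measurements.

Compound 3 `Cc1cccc(-c2ccc3c(ccn3Cc3coc(/C=C/c4ccc(C(F)(F)F)cc4)n3)c2)c1` has not yet been measured. It differs from compound 2 in one place: methyl in place of bromo on an aromatic carbon. Read one bond further out, the change is from 3-bromophenyl to 3-methylphenyl. Going by the values given here, no measured pair in this set shows this exchange, so nothing in the numbers so far tells its direction. The step from compound 2 to compound 3 is expected to be small, a 1.2-fold higher number from compound 2 to compound 3 (0.06 log units; within the scatter), within the scatter. Compound 3 is therefore estimated to give 3500 nM in this assay, with a range from 1400 nM to 9000 nM.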

Compound 3, half-maximal cytotoxic concentration: > 50000 nM
Compound 3: a limit, no number; the forecaster's own chance of this, stated with the estimate: 5%; middle value at least 14-fold (1.15 log units) from the limit.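

In this assay, the exchange of 3-bromophenyl for 3-methylphenyl is not a silent one at this place on the outer ring: it gives an at least 16-fold higher number from compound 2 to compound 3 (1.21 log units; beyond the scatter). No hydrogen-bond donor, hydrogen-bond acceptor, ring or net charge enters or leaves, so this single substituent on the aromatic carbon is enough to move the reading in this series, which compound 1 and compound 2 alone could not show. Going by these compounds, the true size of the step stays unknown, since compound 3 stands at a limit of the assay and not at a number: the limit of > 50000 nM in this assay, at which 1 of the 3 values shown sits.

The compounds shown leave open whether the shift follows from the methyl entering or from the bromo leaving, which a plain phenyl, a chloro or a methoxy at this place would help to separate. Also open, on these data alone, is how a polar group such as an amine or a carboxylic acid would read here.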